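Compound 4: a methoxy swap under a limit

The source may hold more compounds than are shown below. What is called first, only, known or untested is meant among the compounds shown, and "the series" means these compounds.

Measured in a physicochemical assay for pharmacokinetics; on this read-out higher numbers stand for a longer-lived compound and lower numbers for a shorter-lived compound:
- compound 1 `O=C(NCc1ccccc1F)N1C(=O)c2ccccc2S1(=O)=O`: > 166 h
- compound 2 `O=C(OCc1ccccc1)N1C(=O)c2ccccc2S1(=O)=O`: > 166 h
- compound 3 `O=C(CCc1ccccc1)N1C(=O)c2ccccc2S1(=O)=O`: > 166 h

Each of these entries is a limit of the assay and not a number. Compound 1 stands at > 166 h, which is such a limit. The three compounds have this in common: the limit of > 166 h in this assay, at which 3 of the 3 values shown sit. Compound 4 `COc1ccccc1CNC(=O)N1C(=O)c2ccccc2S1(=O)=O` has methoxy in place of fluoro on an aromatic carbon, ortho to a large group (methoxy in place of fluoro on an aromatic carbon). No step beyond the scatter is expected in this assay, and no direction can be named, because of the limit of > 166 h in this assay, at which 3 of the 3 values shown sit. The expected step that the limit leaves unreadable from compound 1 to compound 4 is therefore only a rough estimate. For compound 4 the expected value is 200 h, with an estimated range of 100 h to 400 h. A limit is the likeliest report again.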

Compound 4, half-life: > 166 h
Compound 4 was reported as a limit (the forecaster's own chance of this, stated with the estimate: 80%); the middle value does not contradict the limit.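

No step can be read between compound 1 and compound 4, because both results are limits and not numbers: the limit of > 166 h in this assay, at which 4 of the 4 values shown sit. The compounds shown leave open whether methoxy in place of fluoro changes the result in this assay at all.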